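Butoxy for methoxy on the shared core

A few compounds are considered here, and "the series" means these few. Any claim that something is new, unique, unknown or untested is made for them only; others in the source may bear on it.

The series is a set of thiosemicarbazones assessed in a toxicity assay on MRC5 cells (Homo sapiens) for cytotoxicity, read by MTT assay, with a stated time of 72 h; a higher number here means that more compound is needed for the effect, a lower number that less compound is needed. Compound 1 `CCCCn1cc(/C=N/NC(N)=S)c2cccc(C)c21` gives 31000 nM in this assay. Compound 2 `COc1ccc(/C=N/NC(N)=S)c2ccccc12` gives 42000 nM in this assay. Among the compounds with values here, of the two values shown, compound 2 stands at the higher figure, but its only neighbour compound 1 lies within the scatter of it, so no order between the two can be drawn. Compound 3 `CCCCOc1ccc(/C=N/NC(N)=S)c2ccccc12` has not yet been measured in this assay. It differs from compound 2 by propyl in place of hydrogen on a saturated chain carbon bound to an oxygen on an aromatic ring; cut one bond further out, the same difference reads methyl to butyl, methoxy to butoxy. Within the data shown here, no step between measured compounds covers this change, and the two measured values give no guide to it. The expectation is therefore a small shift, if any, towards a lower number, not clearly beyond the scatter. The step of a 1.4-fold lower number from compound 2 to compound 3 (0.15 log units; within the scatter) is the expected size of the move. Compound 3 is estimated at 30000 nM in this assay, with an expected range from 12000 nM to 80000 nM.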

Compound 3, half-maximal effective concentration: 41000 nM
The estimate for compound 3 lay 1.4-fold (0.14 log units) below the measured number, and the stated range covers the measured number.
By their numbers in this assay, from the lowest: compounds 1, 3 and 2 (each within the scatter of the next).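

In this assay, the first step read at this position, methoxy to butoxy on the shared core, comes to a 1.0-fold lower number from compound 2 to compound 3 (0.01 log units; within the scatter). On a saturated chain carbon bound to an oxygen on an aromatic ring, propyl in place of hydrogen therefore leaves the number inside the scatter, so this extension of the chain gives no readable change in the amount of compound needed for the effect, which the earlier pair of compounds, differing in more than one place, could not show. No supporting measurement bears on why the two numbers stay together, and the result stands as an observation only.

A single step of this kind says nothing about how far the flat reading extends: with only methoxy and butoxy shown, a longer chain such as octyloxy, or a butoxy chain ending in an amine or a carboxylic acid, could still move the number beyond the scatter. As far as these compounds go, whether butoxy behaves the same way on other cores, including the core of compound 1, also remains open.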